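Adding one hydroxy group to compound 1

A few compounds are considered here, and "the series" means these few. Any claim that something is new, unique, unknown or untested is made for them only; others in the source may bear on it.

In an ADME assay on MT4 cells (Homo sapiens) for cytotoxicity, read by MTT assay, with a stated time of 4 days (on this read-out higher numbers stand for lower toxicity in this test and lower numbers for higher toxicity in this test), compound 1 `CC(=O)Nc1ccc2oc(-c3ccccc3)cc(=O)c2c1` gives 184000 nM. Two close relatives carry a trifluoromethyl group: compound 2 `CC(=O)Nc1ccc2oc(-c3cccc(C(F)(F)F)c3)cc(=O)c2c1` gives 10000 nM, and compound 3 `CC(=O)Nc1ccc2oc(-c3ccc(C(F)(F)F)cc3)cc(=O)c2c1` gives 330000 nM. Compound 1 therefore stands level with compound 3, within the scatter, and far from compound 2.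

The unmeasured compound 4 `CC(=O)Nc1ccc2oc(-c3ccccc3)c(O)c(=O)c2c1` keeps the core of compound 1 and alters it in one place: hydroxy in place of hydrogen on an aromatic carbon. In words, this is hydroxy in place of hydrogen on an aromatic carbon.

Among the measured compounds shown here, no measured step adds a hydroxy group or touches this ring, so the two trifluoromethyl steps offer only loose guidance. They show how differently a single replacement of hydrogen can turn out. One gave an 18-fold lower number from compound 1 to compound 2 (1.26 log units; beyond the scatter), a large step, while the other gave a 1.8-fold higher number from compound 1 to compound 3 (0.25 log units; within the scatter), which is no real change. With one large drop and one null result, the safest expectation in this assay is a step that stays within the scatter, leaning slightly towards a lower number, with a real chance of a larger drop. The expected step is a 1.8-fold lower number from compound 1 to compound 4 (0.26 log units; within the scatter). For compound 4 the estimated value is 100000 nM, with an expected range from 15000 nM to 300000 nM.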

Compound 4, half-maximal cytotoxic concentration: 64700 nM
Estimate against measurement, compound 4: 1.5-fold (0.19 log units) above; low and high end bracket the measured number.
By their numbers in this assay, from the lowest: compound 2; then compound 4; then compounds 1 and 3 (each within the scatter of the next).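

This is the first change in the shown series made on the six-membered aromatic ring with 1 oxygen rather than on the phenyl group, and in this assay it gives a 2.8-fold lower number from compound 1 to compound 4 (0.45 log units; beyond the scatter). So this carbon, ortho to the phenyl group, is not a silent spot: a hydroxy group of only 1 heavy atom moves the read-out modestly towards higher toxicity in this test, a smaller move than an 18-fold lower number from compound 1 to compound 2 (1.26 log units; beyond the scatter), yet one that, unlike a 1.8-fold higher number from compound 1 to compound 3 (0.25 log units; within the scatter), lies beyond the scatter. Nothing shown here explains why the number falls with this change, since no supporting measurement accompanies it.

A single group at a single carbon cannot show whether the lower number belongs to the hydroxy group itself or would come with almost any group placed there, and a methoxy group or an amine on the same carbon would help to separate those two readings. On these data alone, it also remains open whether the hydroxy step would keep its size on a compound that carries trifluoromethyl on the phenyl group, as compound 2 and compound 3 do.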